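The source may hold more compounds than are shown below. What is called first, only, known or untested is meant among the compounds shown, and "the series" means these compounds.

Of the compounds shown here, three that share one core have been measured in a functional assay on A-375 cells (Homo sapiens) for inhibition, read by MTT assay, with a stated time of 24 h; on this read-out lower numbers stand for stronger inhibition and higher numbers for weaker inhibition. Compound 1 `CCN1CCN(c2c(CO)c(=O)oc3ccccc23)CC1` gives > 50000 nM, which is a limit of the assay rather than a number (the limit of > 50000 nM in this assay, at which 1 of the 3 values shown sits). Compound 2 `O=c1oc2ccccc2c(N2CCN(c3ccccc3)CC2)c1CO` gives 17300 nM in this assay, and compound 3 `COc1ccc(N2CCN(c3c(CO)c(=O)oc4ccccc34)CC2)cc1` gives 7230 nM. Compound 3 therefore holds the lowest of the two numbers shown, and the nearest number belongs to compound 2. Going from the one to the other, the step was a 2.4-fold lower number from compound 2 to compound 3 (0.38 log units; beyond the scatter). The steps of an at least 2.8-fold lower number from compound 1 to compound 2 (0.46 log units; beyond the scatter) and an at least 6.9-fold lower number from compound 1 to compound 3 (0.83 log units; beyond the scatter) start from a limit, so only a floor for their size is known.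

Compound 4 `O=c1oc2ccccc2c(N2CCN(c3cccc(Cl)c3)CC2)c1CO` has not yet been measured in this assay. It differs from compound 3 in one place: 3-chlorophenyl in place of 4-methoxyphenyl on an amine nitrogen in a ring. Among the compounds with values here, no measured step exchanges 4-methoxyphenyl for 3-chlorophenyl; the step from compound 2 to compound 3 concerns only methoxy against hydrogen, so it gives little guidance here. The expected step is a 1.4-fold higher number from compound 3 to compound 4 (0.14 log units; within the scatter), judged to lie within the usual scatter. Compound 4 is therefore estimated at 10000 nM, with a range from 4000 nM to 25000 nM.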

Compound 4, half-maximal inhibitory concentration: 40500 nM
Compound 4: the middle estimate sits 4.1-fold (0.61 log units) below what was measured; measured number outside the range, above it.
By their numbers in this assay, from the lowest: compound 3; then compound 2; then compound 4. At a limit, above all of these: compound 1.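

A group on the phenyl ring can move the number either way: chloro in place of hydrogen gives a 2.3-fold higher number from compound 2 to compound 4 (0.37 log units; beyond the scatter) and so runs opposite to the earlier methoxy step. Exchanging 4-methoxyphenyl for 3-chlorophenyl gives a 5.6-fold higher number from compound 3 to compound 4 (0.75 log units; beyond the scatter) even though each group holds one six-membered aromatic ring of carbon only, so this position responds to what the ring carries. The value of compound 1 is a limit, so an at least 1.2-fold lower number from compound 1 to compound 4 (0.09 log units; that floor lies within the scatter) gives only a floor and does not separate 3-chlorophenyl from ethyl.

Nothing shown gives a reason for these steps. As far as these compounds go, it also stays open whether the group or its place on the ring matters more, and how 4-chlorophenyl, 3-methoxyphenyl or a phenyl carrying an amine would compare.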